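The source may hold more compounds than are shown below. What is called first, only, known or untested is meant among the compounds shown, and "the series" means these compounds.

In a functional assay on MCF7 cells (Homo sapiens) for antiproliferative activity, read by MTT assay, with a stated time of 48 h (on this read-out lower numbers stand for stronger inhibition and higher numbers for weaker inhibition), compound 3 (`CC(=O)Oc1c(Br)cc(Br)cc1/C=C1\N=C(c2ccccc2)N(c2ccccc2)NC1=O`) gives 19400 nM, within the scatter of compound 1 (`CC(=O)Oc1c(Br)cc(Br)cc1/C=C1\N=C(c2ccccc2)N(C(N)=S)NC1=O`) at 28500 nM, while compound 2 (`COc1cc(C2=N/C(=C\c3cc(Br)cc(Br)c3OC(C)=O)C(=O)NN2c2ncc(-c3ccccc3)s2)cc(OC)c1OC`) gives 410 nM and so stands well apart from both on the side of stronger inhibition. Compound 4 (`COc1cc(C2=N/C(=C\c3cc(Br)cc(Br)c3OC(C)=O)C(=O)NN2c2ccccc2)cc(OC)c1OC`) differs from compound 3 by one change: 3,4,5-trimethoxyphenyl in place of phenyl on a carbon with a double bond to nitrogen. Going by the values given here, the only measured step, a 1.5-fold lower number from compound 1 to compound 3 (0.17 log units; within the scatter), lies within the scatter and sits at a different place, on an amine nitrogen in a ring, so it says little here. As far as these compounds go, compound 2 also carries 3,4,5-trimethoxyphenyl but differs from compound 3 on that ring nitrogen as well, so the share of this group in the gap is unknown. A moderate move to lower numbers in this assay is expected, beyond the scatter. The expected step is a 3.9-fold lower number from compound 3 to compound 4 (0.59 log units; beyond the scatter). For compound 4 the estimated value is 5000 nM, with an expected range of 900 nM to 20000 nM.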

Compound 4, half-maximal inhibitory concentration: 350 nM
Beside the measured number, compound 4's estimate is 14-fold (1.15 log units) above it; the whole stated range lies above it.
By their numbers in this assay, from the lowest: compounds 4 and 2 (each within the scatter of the next); then compounds 3 and 1 (each within the scatter of the next).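

In this assay, 3,4,5-trimethoxyphenyl in place of phenyl on the carbon with a double bond to nitrogen gives a 55-fold lower number from compound 3 to compound 4 (1.74 log units; beyond the scatter) and shows this position to be highly sensitive to the change. With 3,4,5-trimethoxyphenyl in place, phenyl replacing 5-phenyl-1,3-thiazol-2-yl on the amine nitrogen in the ring gives a 1.2-fold lower number from compound 2 to compound 4 (0.07 log units; within the scatter) and no readable difference. Nothing at hand accounts for the size of the step. Still open, as far as these compounds go, is whether the three methoxy groups are all needed at this position, and whether an aminophenyl or carboxyphenyl group there would hold the gain.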